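Compound 3 set against compound 1

A few compounds are considered here, and "the series" means these few. Any claim that something is new, unique, unknown or untested is made for them only; others in the source may bear on it.

- Compound 1 `CC(=O)OC1CCC(CN2CCN(c3cc(=O)c4cc(C(F)(F)F)cc([N+](=O)[O-])c4s3)CC2)CC1`: < 0.15 h (a limit, not a number)
- Compound 2 `O=C(OC1CCC(CN2CCN(c3cc(=O)c4cc(C(F)(F)F)cc([N+](=O)[O-])c4s3)CC2)CC1)c1ccco1`: 0.075 h

Both results come from an ADME assay on cells (Hepatocyte, Homo sapiens) for metabolic stability; on this read-out higher numbers stand for a longer-lived compound and lower numbers for a shorter-lived compound. Going by these compounds, compound 1 stands only at a limit, < 0.15 h, so its exact place on the scale is unknown. The evidence has this restriction: the limit of < 0.15 h in this assay, at which 1 of the 2 values shown sits.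

Compound 3 `O=C(OC1CCC(CN2CCN(c3cc(=O)c4cc(C(F)(F)F)cc([N+](=O)[O-])c4s3)CC2)CC1)c1cccs1` carries one change from compound 1: thiophen-2-yl in place of methyl on a carbonyl carbon. Going by the values given here, the one measured step that bears on it is a step that the limit leaves unreadable from compound 1 to compound 2, where furan-2-yl enters at the same place. That step gives no usable size or direction, so the expectation rests on the number for the furan-2-yl compound. With compound 2 at 0.075 h as the only reference, compound 3 is expected to fall in the same short-lived region of this assay.

The expected step is a step that the limit leaves unreadable from compound 1 to compound 3, and its size remains poorly defined. For compound 3 the estimate is 0.08 h, with an expected range of 0.04 h to 0.15 h.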

Compound 3, half-life: 0.0917 h
Compound 3: the middle estimate sits 1.1-fold (0.06 log units) below what was measured; the range from low to high includes it.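

In this assay, going by these compounds alone, thiophen-2-yl in place of furan-2-yl on a carbonyl carbon gives a 1.2-fold higher number from compound 2 to compound 3 (0.09 log units; within the scatter), the first step at this position that can be read. The two five-membered aromatic rings therefore cannot be told apart here, and compound 3 and compound 2 both sit in the short-lived region of the scale. Compound 1 stands only at a limit, < 0.15 h, and the steps from it to either ring-bearing compound cannot be read: the limit of < 0.15 h in this assay, at which 1 of the 3 values shown sits.

Going by these compounds, whether either aromatic ring differs from methyl on this carbonyl carbon, in either direction, remains open, and so does whether any group at this place moves the half-life beyond the scatter. Also open, on these data alone, is how a saturated ring such as cyclohexyl, a chain carrying an amine, or an amide nitrogen in place of the oxygen next to the carbonyl group would read in this assay.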